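Morpholine amide in place of methylimidazolidinone on a shared core

A few compounds are considered here, and "the series" means these few. Any claim that something is new, unique, unknown or untested is made for them only; others in the source may bear on it.

Measured compounds:
compound 1 `CN1CCN(CCOc2nn(-c3ccccc3F)c3ccc(F)cc23)C1=O`: 1000 mL/min/kg
compound 2 `CC(C)(O)CC(=O)N1CC[C@H]2CN(c3cccc4c3cnn4-c3ccccc3F)C(=O)[C@H]21`: 58.3 mL/min/kg
compound 3 `O=C1C2CN(Cc3ccccc3)CC2CN1c1cccc2c1cnn2-c1ccccc1F`: 900 mL/min/kg

In an ADME assay on liver for metabolic stability, with Liver microsome (Homo sapiens) as the target, using microsomes and NADPH, with a stated time of 30 min, tested at 0.5 uM (on this read-out higher numbers stand for fast clearance and lower numbers for slow clearance), compound 1 has the highest number of the three. Compound 3 lies close to it, within the scatter, while compound 2 gives a number far lower, beyond the scatter. Compound 4 `O=C(COc1nn(-c2ccccc2F)c2ccc(F)cc12)N1CCOCC1` is not yet measured. It differs from compound 1 in one place: (morpholin-4-yl)carbonyl in place of (3-methyl-2-oxoimidazolidin-1-yl)methyl on a saturated chain carbon bound to an oxygen on an aromatic ring. For the measured compounds named here, no measured pair shows this kind of change, so the data give no guide to its size. The step from compound 1 to compound 4 is expected to be small, a 1.5-fold lower number from compound 1 to compound 4 (0.19 log units; within the scatter), likely within the scatter. Compound 4 is therefore expected to give about 650 mL/min/kg in this assay, within a range from 250 mL/min/kg to 1000 mL/min/kg.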

Compound 4, clearance: 117 mL/min/kg
For compound 4 the middle estimate is 5.6-fold (0.74 log units) above the measured one, outside the stated range (below it).
By their numbers in this assay, from the lowest: compounds 2 and 4 (each within the scatter of the next); then compounds 3 and 1 (each within the scatter of the next).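

For the compounds shown here, on the saturated chain carbon bound to an oxygen on an aromatic ring, a single change can now be read for the first time. In this assay, (morpholin-4-yl)carbonyl in place of (3-methyl-2-oxoimidazolidin-1-yl)methyl gives an 8.5-fold lower number from compound 1 to compound 4 (0.93 log units; beyond the scatter) with the same count of heavy atoms, so this position can shift clearance beyond the scatter. Nothing available here explains the shift.

Still open, going by these compounds, is which part of the new group matters, the carbonyl or the morpholine ring. A piperidine amide or a dimethylamide at this position would help separate the two.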